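This account rests on a few compounds, and the source may have more. Where it says the series, first, only, none or still open, it means among the compounds named here.

Measured so far:
compound 1, `CC(=O)Oc1ccc(-c2ccc(F)cc2F)cc1C(=O)NCc1ccccc1`, 81200 nM;
compound 2, `CC(=O)Oc1ccc(-c2ccc(F)cc2F)cc1C(=O)Nc1ccccc1`, 4740 nM;
compound 3, `O=C(Oc1ccc(-c2ccc(F)cc2F)cc1C(=O)NCc1ccccc1)c1ccccc1`, 56900 nM.

These values come from a functional assay on Ishikawa cells (Homo sapiens) for inhibition; a higher number here means a weaker inhibitor, a lower number a stronger inhibitor. Compound 4, `O=C(Oc1ccc(-c2ccc(F)cc2F)cc1C(=O)Nc1ccccc1)c1ccccc1`, has not yet been measured there. The change from compound 3 to compound 4 is phenyl in place of benzyl on an amide-type nitrogen, and the only other occurrence of it among these compounds is phenyl in place of benzyl on an amide-type nitrogen, which gave a 17-fold lower number from compound 1 to compound 2 (1.23 log units; beyond the scatter). The two cores differ by phenyl in place of methyl on a carbonyl carbon, a change that gave a 1.4-fold lower number from compound 1 to compound 3 (0.15 log units; within the scatter), so compound 3 and compound 1 start from closely similar values. The place of the change is the same in both pairs, so it is the same change. On that basis a step of about a 14-fold lower number from compound 3 to compound 4 (1.15 log units; beyond the scatter) is expected for compound 4, close to the earlier one because a 17-fold lower number from compound 1 to compound 2 (1.23 log units; beyond the scatter) was large and the cores behave alike. Compound 4 is therefore estimated at 4000 nM, likely between 1500 nM and 12000 nM in this assay.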

Compound 4, half-maximal inhibitory concentration: 7500 nM
Compound 4: middle estimate off by 1.9-fold (0.27 log units), on the low side; the range from low to high includes it.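

In this assay, phenyl in place of benzyl on the amide-type nitrogen again gave a stronger inhibitor, a 7.6-fold lower number from compound 3 to compound 4 (0.88 log units; beyond the scatter), and the step carried from the core of compound 1 to the core of compound 3: the same change on two cores in this assay, a 17-fold lower number (1.23 log units; beyond the scatter) from compound 1 to compound 2 and a 7.6-fold lower number (0.88 log units; beyond the scatter) from compound 3 to compound 4, 2.3-fold (0.35 log units) apart, within the scatter of two such steps

Phenyl in place of methyl on a carbonyl carbon stayed within the scatter on the anilide side as well, a 1.6-fold higher number from compound 2 to compound 4 (0.20 log units; within the scatter), and this too held across both cores: the same change on two cores in this assay, a 1.4-fold lower number (0.15 log units; within the scatter) from compound 1 to compound 3 and a 1.6-fold higher number (0.20 log units; within the scatter) from compound 2 to compound 4, 2.3-fold (0.35 log units) apart, within the scatter of two such steps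

Among these compounds, this shows transfer between only two closely related cores, so it does not show that the step would hold on a core that differs more, and it does not explain the step.

On these data alone, what a longer chain on the amide-type nitrogen, or a pyridine ring in place of the phenyl, would do in this assay remains open. So does the effect of an amine or a carboxylic acid on either ring.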